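Resolving compound 3: the drawn R enantiomer

This account rests on a few compounds, and the source may have more. Where it says the series, first, only, none or still open, it means among the compounds named here.

Compound 3 `CC1CC/C(=N\Nc2ccccc2)c2ncc(/C=C/C(=O)O)c(=O)n21` carries the vinyl acid on the shared core and is drawn without a configuration at the methyl-bearing ring carbon. In a functional assay on the whole organism with Rattus norvegicus as the target (on this read-out higher numbers stand for an effect only at larger amounts of compound and lower numbers for an effect already at smaller amounts), compound 3 gives 0.27 umol/kg, the lowest number of the three measured; the nearest is compound 1 `C[C@H]1CC/C(=N\Nc2ccccc2)c2ncc(C(=O)O)c(=O)n21`, which in this assay gives 0.3 umol/kg, within the scatter of compound 3. Far away stands compound 2 `C[C@@H]1CC/C(=N\Nc2ccccc2)c2ncc(C(=O)O)c(=O)n21`, which in this assay gives 54.8 umol/kg.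

Compound 4 `C[C@@H]1CC/C(=N\Nc2ccccc2)c2ncc(/C=C/C(=O)O)c(=O)n21` is the next compound for this assay. Its difference from compound 3 is this: the two compounds have the same atoms and bonds; at least one stereo element is drawn with a configuration in one of them and without one in the other: 1 of 3 stereo elements differ; a stereocentre at a saturated ring carbon is drawn without a configuration in compound 3 and R in compound 4.

For the measured compounds named here, the one measured step that bears on this is a 180-fold higher number from compound 1 to compound 2 (2.26 log units; beyond the scatter), and it rests on the fact that compounds 1 and 2 differ only in the configuration as drawn: the configuration drawn at that ring carbon alone separates the two, with the R drawing on the weak side. Compound 3 as drawn must contain both configurations, so its number sits where the S form carries it. Compound 4 as the R drawing is therefore expected to fall toward compound 2, with a step of a 110-fold higher number from compound 3 to compound 4 (2.05 log units; beyond the scatter) in this assay. For compound 4 the estimate in this assay is 30 umol/kg, with the range 5 umol/kg to 150 umol/kg.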

Compound 4, dose for 50% inhibition: > 100 umol/kg
Compound 4 ended at the assay's limit; the forecaster's own chance of this, stated with the estimate: 10%; middle value at least 3.3-fold (0.52 log units) from the limit.
By their numbers in this assay, from the lowest: compounds 3 and 1 (each within the scatter of the next); then compound 2. At a limit, above all of these: compound 4.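

In this assay compound 4 gives > 100 umol/kg, which is a limit of the assay and not a number. Drawing the saturated ring carbon as R gives an at least 370-fold higher number from compound 3 to compound 4 (2.56 log units; beyond the scatter), so the large dependence on configuration at this carbon, so far seen only between compounds 1 and 2 with carboxy, also appears with 2-carboxyethenyl, with one caution about the reference point: the fact that one of compounds 3 and 4 is drawn with a defined configuration and the other without, at the place where they differ. With the R drawing held, 2-carboxyethenyl in place of carboxy on an aromatic carbon gives an at least 1.8-fold higher number from compound 2 to compound 4 (0.26 log units; that floor lies within the scatter), so no change can be claimed for this swap in the R series, and the earlier match between compounds 1 and 3 does not extend to a defined effect of the swap here.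

Still open, as far as these compounds go, are how the S drawing of the 2-carboxyethenyl compound compares with compound 1 and how far past the limit compound 4 lies. Also open, from the compounds shown here alone, is whether an ester or an amide in place of the carboxylic acid, or an ethyl in place of the methyl on the ring carbon, keeps this gap between the two configurations.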